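The source may hold more compounds than are shown below. What is called first, only, known or untested is meant among the compounds shown, and "the series" means these compounds.

Three compounds share one core and were measured in a functional assay on HeLa cells (Homo sapiens) for cytotoxicity, read by MTT assay, with a stated time of 48 h; a lower number here means a stronger inhibitor, a higher number a weaker inhibitor. Compound 1 `O=C(O)CN1C(=O)/C(=C/c2nc3ccccc3n2Cc2ccc(F)cc2)SC1=S` gives 13900 nM, compound 2 `O=C(O)CN1C(=O)/C(=C/c2nc3ccccc3n2Cc2ccc(Cl)cc2)SC1=S` gives 8720 nM, and compound 3 `Cc1ccc(Cn2c(/C=C3\SC(=S)N(CC(=O)O)C3=O)nc3cc(Cl)ccc32)cc1` gives 21400 nM. The difference between the core of compound 3 and that of compound 2 is not broken down here; the number for compound 3 is higher than that for compound 2, beyond the scatter, while compound 3 and compound 1 lie within the scatter of each other. Between compound 2 and compound 1 the change is fluoro in place of chloro on an aromatic carbon, and it made a 1.6-fold higher number from compound 2 to compound 1 (0.20 log units; within the scatter).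

Compound 4 `Cc1ccc(Cn2c(/C=C3\SC(=S)N(CC(=O)O)C3=O)nc3cc(F)ccc32)cc1` has not yet been measured. It differs from compound 3 by fluoro in place of chloro on an aromatic carbon. This is the same kind of change as that from compound 2 to compound 1, but not the same: in compound 1 the new group sits on an aromatic carbon of a six-membered aromatic ring of carbon only, para to a large group, whereas in compound 4 it sits on a ring that is part of a fused or bridged system of two rings, meta to a fused ring and para to a fused ring.

Because the earlier step of a 1.6-fold higher number from compound 2 to compound 1 (0.20 log units; within the scatter) stayed within the scatter, a similarly small step a 1.4-fold higher number from compound 3 to compound 4 (0.15 log units; within the scatter) is expected. Compound 4 is therefore estimated at 30000 nM, most likely between 15000 nM and 60000 nM.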

Compound 4, half-maximal inhibitory concentration: 2380 nM
The estimate for compound 4 lay 13-fold (1.10 log units) above the measured number; the measured number lies below the stated range.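

In this assay, fluoro in place of chloro on an aromatic carbon gave a 9.0-fold lower number from compound 3 to compound 4 (0.95 log units; beyond the scatter), and the same kind of change did not carry over from one core to the other: the same change on two cores in this assay, a 1.6-fold higher number (0.20 log units; within the scatter) from compound 2 to compound 1 and a 9.0-fold lower number (0.95 log units; beyond the scatter) from compound 3 to compound 4, 14-fold (1.16 log units) apart, beyond the scatter of two such steps

So in this series, a step seen for this change on one core could not be assumed to hold on another. The two steps differ in more than the core, since the new fluoro stands on a ring that is part of a fused or bridged system of two rings in compound 4 but on a six-membered aromatic ring outside that system in compound 1, so the pairs do not show whether the core or the place of the change accounts for the gap, nor do two pairs establish any general rule.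

The compounds shown leave open whether bromo or methoxy on that same aromatic carbon of the fused system would follow fluoro or chloro. They also leave open how an amide in place of the carboxylic acid would read in this assay.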